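One Methyl on an Aromatic Oxygen: What to Expect

The compounds below may be only part of what the source reports. "The series", "measured", "known", "first", "only" and "open" are said of these compounds alone.

Three compounds have been measured in a functional assay on HT-29 cells (Homo sapiens) for inhibition, read by sulforhodamine B assay, with a stated time of 48 h; on this read-out lower numbers stand for stronger inhibition of growth and higher numbers for weaker inhibition of growth:

Compound 1 `CCOC(=O)C1=C(C)NC(=O)NC1c1ccc(SC)cc1` gives 10.2 ug/mL.
Compound 2 `CCOC(=O)C1=C(C)NC(=S)NC1c1ccc(O)c(O)c1` gives 33.7 ug/mL.
Compound 3 `CCOC(=O)C1=C(C)NC(=S)NC1c1ccc(F)cc1` gives 26.5 ug/mL.

Compound 2 carries the highest of the three numbers. Compound 3 sits nearest to it, and the two values lie within the usual scatter of each other, so nothing separates them. Compound 1 stands furthest away, with a lower number that lies beyond the scatter.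

Compound 4 `CCOC(=O)C1=C(C)NC(=S)NC1c1ccc(O)c(OC)c1` differs from compound 2 in one place: methyl in place of hydrogen on an oxygen on an aromatic ring. For the measured compounds named here, no measured pair in this set shows that change, so there is no step to lean on. The change is small, and in the absence of any comparable pair the reasonable expectation is a step that stays within the scatter, with perhaps a slight lowering of the number. The estimate therefore means a step of a 1.3-fold lower number from compound 2 to compound 4 (0.13 log units; within the scatter), which is expected rather than known. Compound 4 is accordingly expected to give about 25 ug/mL, with a plausible range from 10 ug/mL to 60 ug/mL.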

Compound 4, concentration for 50% growth inhibition: 34.9 ug/mL
Compound 4: middle estimate off by 1.4-fold (0.14 log units), on the low side; the range from low to high includes it.
By their numbers in this assay, from the lowest: compound 1; then compounds 3, 2 and 4 (each within the scatter of the next).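

In this assay, for the compounds shown here, the pair gives the first direct reading of methyl in place of hydrogen on an oxygen on an aromatic ring, and the step of a 1.0-fold higher number from compound 2 to compound 4 (0.02 log units; within the scatter) shows that this change leaves the two compounds indistinguishable. Going by these compounds alone, for this pair, then, hydroxy and methoxy at this oxygen cannot be told apart on this read-out, which the earlier compounds, none of them differing from another in one place, could not show. Nothing measured here offers an explanation for this result.

The compounds shown leave open whether a longer chain such as ethyl on that oxygen, or an amine or a carboxylic acid in place of the hydroxy, would stay as close to compound 2. They also leave open whether the same change would read alike on the core of compound 1.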